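Removing a Methyl from the Aryl Group of Compound 2

The compounds below may be only part of what the source reports. "The series", "measured", "known", "first", "only" and "open" are said of these compounds alone.

Within the data shown here, compound 2 `Cc1ccc(Nc2nc(SCc3cn(CC(=O)NC(=O)Nc4ccccn4)nn3)nc(-c3ccc(C)cc3)c2C#N)cc1` gives 9890 nM in a functional assay on MGC-803 cells (Homo sapiens) for inhibition, read by MTT assay, with a stated time of 72 h (on this read-out lower numbers stand for stronger inhibition and higher numbers for weaker inhibition), the second highest of the three numbers known so far. Compound 3 `Cc1ccc(-c2nc(SCc3cn(CC(=O)NC(=O)Nc4ccccn4)nn3)nc(Nc3cccc(C(F)(F)F)c3)c2C#N)cc1` gives 7580 nM, and compound 1 `Cc1ccc(-c2nc(SCc3cn(CC(=O)NC(=O)Nc4ccccn4)nn3)nc(Nc3ccc(C(C)C)cc3)c2C#N)cc1` gives 19300 nM. Compound 4 `Cc1ccc(Nc2nc(SCc3cn(CC(=O)NC(=O)Nc4ccccn4)nn3)nc(-c3ccccc3)c2C#N)cc1` differs from compound 2 by hydrogen in place of methyl on an aromatic carbon. Among the measured compounds shown here, none of the measured steps touches this carbon-linked aryl group; all of them alter the aryl on nitrogen, where a 2.0-fold lower number from compound 1 to compound 2 (0.29 log units; within the scatter) and a 1.3-fold lower number from compound 2 to compound 3 (0.12 log units; within the scatter) stayed within the scatter and a 2.5-fold lower number from compound 1 to compound 3 (0.41 log units; beyond the scatter) was only modest. For the measured compounds named here, the loss of a small alkyl group elsewhere thus did little, and there is no direct precedent for this position. Compound 4 is therefore expected to show a 1.1-fold higher number from compound 2 to compound 4 (0.05 log units; within the scatter), an estimate of 11000 nM with a range from 4000 nM to 30000 nM.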

Compound 4, half-maximal inhibitory concentration: 7870 nM
Compound 4: the middle estimate sits 1.4-fold (0.15 log units) above what was measured; low and high end bracket the measured number.
By their numbers in this assay, from the lowest: compounds 3, 4, 2 and 1 (each within the scatter of the next, the first and the last beyond it).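

The carbon-linked aryl group gets its first measured step with a 1.3-fold lower number from compound 2 to compound 4 (0.10 log units; within the scatter) in this assay and this stays within the usual scatter of repeat measurements. The methyl on this ring is therefore not needed to hold activity at this modest level, and the change from 4-methylphenyl to phenyl leaves the two numbers indistinguishable. Nothing available explains this result. Still open, going by these compounds, is whether this position tolerates only hydrogen and methyl or also accepts something larger or charged, such as an amine, a carboxylic acid or a longer chain.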